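Two Carbons Added to the Chain: Expected Partition Shift

A few compounds are considered here, and "the series" means these few. Any claim that something is new, unique, unknown or untested is made for them only; others in the source may bear on it.

compound 1, `CCOC(=O)C1(C)CCC=[N+]1[O-]`: 0.15
compound 2, `CCCC1(C(N)=O)CCC=[N+]1[O-]`: 0.211

In a physicochemical assay for lipophilicity, in phosphate buffer, measured as octanol-water partition, at pH 7.0 (a lower number here means a more polar compound, a higher number a more lipophilic compound), compound 1 gives 0.15 and compound 2 gives 0.211; the two values lie within the scatter of each other, so compound 2 stands level with compound 1. Compound 3, `CCCCCC1(C(N)=O)CCC=[N+]1[O-]`, is not yet measured. It differs from compound 2 in one place: ethyl in place of hydrogen on a saturated chain carbon, three bonds along the chain from a saturated ring carbon. Among the measured compounds shown here, no measured pair here shows this kind of change, so the size of the step rests on expectation alone. A gain of two carbons is expected to raise the partition coefficient by about a number 0.99 log units higher from compound 2 to compound 3 (beyond the scatter). Compound 3 is therefore estimated at 1.2, between 0.8 and 1.6.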

Compound 3, partition coefficient: 2.72
Beside the measured number, compound 3's estimate is 1.52 log units below it; measured number outside the range, above it.
By their numbers in this assay, from the lowest: compounds 1 and 2 (each within the scatter of the next); then compound 3.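

Ethyl in place of hydrogen on a saturated chain carbon, three bonds along the chain from a saturated ring carbon, gives the first step with a measured size in this set: in this assay the number moves a number 2.51 log units higher from compound 2 to compound 3 (beyond the scatter) and the change is large. Until now, no pair differing in one place had shown what this position can do. Nothing available explains the size of this step.

With a single step at this position, no trend along the chain can be drawn. As far as these compounds go, whether a longer chain would extend the rise, or how an amine or a carboxylic acid at the same place would read, stays open.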